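Notes on aryl variation at the saturated ring carbon

The source may hold more compounds than are shown below. What is called first, only, known or untested is meant among the compounds shown, and "the series" means these compounds.

Compound 1 `COc1cc(N2C(N)=C(C#N)C(c3ccc([N+](=O)[O-])cc3)C3=C2CC(C)(C)CC3=O)cc(OC)c1OC` carries a 4-nitrophenyl group on the saturated ring carbon of the shared core. Among the measured compounds shown here, in a functional assay on Ehrlich cells (Mus musculus) for cytotoxicity, tested at 50 ug/mL (on this read-out higher numbers stand for a stronger effect at the one concentration tested and lower numbers for a weaker effect), compound 1 gives 70%, the second highest of the three numbers so far. Compound 3 `COc1cc(N2C(N)=C(C#N)C(c3ccc(Cl)cc3Cl)C3=C2CC(C)(C)CC3=O)cc(OC)c1OC` gives 95% in this assay, and compound 2 `COc1cc(N2C(N)=C(C#N)C(c3c(O)ccc4ccccc34)C3=C2CC(C)(C)CC3=O)cc(OC)c1OC` gives 15%.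

The measured steps all change the aryl group itself: a number 25 percentage points higher from compound 1 to compound 3 (beyond the scatter) and a number 55 percentage points lower from compound 1 to compound 2 (beyond the scatter); between the two replacements, a number 80 percentage points higher from compound 2 to compound 3 (beyond the scatter). Compound 4 `COc1cc(N2C(N)=C(C#N)C(c3cccc([N+](=O)[O-])c3)C3=C2CC(C)(C)CC3=O)cc(OC)c1OC` differs from compound 1 only in this way: 3-nitrophenyl in place of 4-nitrophenyl on a saturated ring carbon. The nitro group stays, the ring stays, only its attachment changes, so neither measured step speaks directly to it; they show only that a wholly different aryl group can shift the number a lot, while the repositioning here is a far smaller structural change than either.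

Compound 4 is therefore expected to stay close to compound 1, with an estimate of 68%, the likely range running from 50% to 86%. The expected step is a number 2 percentage points lower from compound 1 to compound 4 (within the scatter), which is within the scatter.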

Compound 4, a percentage reported as activity, at one concentration (the size of the read-out at that concentration, not a potency): 30%
For compound 4 the middle estimate is 38 percentage points above the measured one, and the stated range ends above it.
By their numbers in this assay, from the lowest: compound 2; then compound 4; then compound 1; then compound 3.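

In this assay, moving the nitro group from the 4-nitrophenyl to the 3-nitrophenyl arrangement gives a number 40 percentage points lower from compound 1 to compound 4 (beyond the scatter) even though the two groups match in atoms and in every feature counted, so at this saturated ring carbon the attachment pattern within a nitrophenyl group can alone produce a large step. The 3-nitrophenyl group also sits well apart from the 2,4-dichlorophenyl group, with a number 65 percentage points lower from compound 3 to compound 4 (beyond the scatter) as the step, yet it remains separated from the 2-hydroxynaphthalen-1-yl group by a number 15 percentage points higher from compound 2 to compound 4 (beyond the scatter) as a modest step, so the two nitrophenyl isomers occupy clearly different places among the four aryl groups. Nothing available explains why the shift of the nitro group changes the read-out so strongly.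

Still open, going by these compounds, is whether the same sensitivity to attachment holds for other substituents on the phenyl ring, such as an amine or a carboxylic acid in place of the nitro group. The single concentration also leaves open whether these steps would persist across a range of concentrations.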